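The source may report more compounds than this note shows. Statements on the series, on what has been measured and on what is new or still open speak of the compounds shown alone.

Compound 1 `O=C(/C=C/c1ccc2c(c1)B(O)OC2)c1ccc(Br)cc1` carries a 4-bromophenyl group on the carbonyl carbon of the shared core. In an ADME assay on L929 cells (Mus musculus) for cytotoxicity, read by resazurin assay, with a stated time of 72 h (on this read-out higher numbers stand for weaker inhibition and lower numbers for stronger inhibition), compound 1 gives > 10 ug/mL, which is a limit of the assay and not a number. Compound 2 `O=C(/C=C/c1ccc2c(c1)B(O)OC2)c1ccc(OCc2ccccc2)cc1` has benzyloxy in place of bromo on an aromatic carbon, and in this assay compound 2 gives > 10 ug/mL, again a limit. Compound 3 `O=C(/C=C/c1ccc2c(c1)B(O)OC2)c1ccc([N+](=O)[O-])cc1` has nitro in place of bromo on an aromatic carbon, and in this assay compound 3 gives > 10 ug/mL, also a limit. The three steps among them, a step that the two limits leave unreadable from compound 1 to compound 2, a step that the two limits leave unreadable from compound 1 to compound 3 and a step that the two limits leave unreadable from compound 2 to compound 3, are therefore unreadable because of the limit of > 10 ug/mL in this assay, at which 3 of the 3 values shown sit. Compound 1 thus stands at the same limit as every other measured compound, with no number of its own.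

Compound 4 `O=C(/C=C/c1ccc2c(c1)B(O)OC2)c1cccs1` differs from compound 1 by thiophen-2-yl in place of 4-bromophenyl on a carbonyl carbon. Among the compounds with values here, no measured step exchanges the whole group on the carbonyl carbon; the three exchanges on an aromatic carbon are the only comparisons at hand, and none of them yields a readable size. Nothing in the measured values therefore points to a step in either direction beyond the scatter. Compound 4 is expected to give about 15 ug/mL, within 7 ug/mL to 40 ug/mL, most likely reported again only as a limit. The step from compound 1 to compound 4 that this estimate means is expected to be a step that the limit leaves unreadable from compound 1 to compound 4.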

Compound 4, half-maximal inhibitory concentration: > 10 ug/mL
Compound 4: no number, only a limit; the forecaster's own chance of this, stated with the estimate: 75%; the middle value does not contradict the limit.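

In this assay compound 4 gives only a limit, as compound 1 does, so the step between compound 1 and compound 4 cannot be read, because both values sit at the same limit: the limit of > 10 ug/mL in this assay, at which 4 of the 4 values shown sit.

The compounds shown leave open whether any of these groups differs from another in this assay, as none of the four has a number of its own.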